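The source may report more compounds than this note shows. Statements on the series, on what has been measured and on what is new or still open speak of the compounds shown alone.

Of the compounds shown here, three built on one shared core have been tested in a functional assay on HepG2 cells (Homo sapiens) for antiproliferative activity, read by MTT assay, with a stated time of 48 h; on this read-out lower numbers stand for stronger inhibition and higher numbers for weaker inhibition. Compound 1 `Cc1ccc(-c2nc3ccc(Cl)cc3c(=O)[nH]2)cc1` gives 9.86 ug/mL, compound 2 `Cc1ccc(-c2nc(N)c3cc(Cl)ccc3n2)cc1` gives 14.5 ug/mL, and compound 3 `Cc1ccc(-c2nc(NN)c3cc(Cl)ccc3n2)cc1` gives 4.17 ug/mL, the lowest of the three numbers. Within the data shown here, the only comparable step, a 3.5-fold lower number from compound 2 to compound 3 (0.54 log units; beyond the scatter), came from amino in place of hydrogen on a nitrogen on an aromatic ring. Compound 4 `Cc1ccc(-c2nc(NOC(=O)c3ccccc3)c3cc(Cl)ccc3n2)cc1` alters that same nitrogen once more: benzoyloxy in place of amino on a nitrogen on an aromatic ring. Among the measured compounds shown here, no measured compound carries a benzoyloxy group, so the sole guide is the step of a 3.5-fold lower number from compound 2 to compound 3 (0.54 log units; beyond the scatter), which accompanied the gain of the amino group that compound 4 now loses. Compound 4 is therefore expected to show a 1.7-fold higher number from compound 3 to compound 4 (0.22 log units; within the scatter), with an estimated 7 ug/mL and a range from 2.5 ug/mL to 20 ug/mL.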

Compound 4, half-maximal inhibitory concentration: 12.1 ug/mL
Beside the measured number, compound 4's estimate is 1.7-fold (0.24 log units) below it; the measured number falls inside the stated range.
By their numbers in this assay, from the lowest: compound 3; then compounds 1, 4 and 2 (each within the scatter of the next).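

Placing benzoyloxy instead of amino on this nitrogen brings a 2.9-fold higher number from compound 3 to compound 4 (0.46 log units; beyond the scatter), so the lower number seen with the amino group is not kept with this much larger group. Set against a plain hydrogen on the same nitrogen, benzoyloxy gives a 1.2-fold lower number from compound 2 to compound 4 (0.08 log units; within the scatter), so adding the benzene ring and carbonyl leaves the number level within the scatter. Nothing measured here explains either step. From the compounds shown here alone, it remains open whether a smaller acetyl or methyl group on this nitrogen would bring the number nearer to that of the amino group.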